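Notes on the step from compound 2 to compound 4

The compounds below may be only part of what the source reports. "The series", "measured", "known", "first", "only" and "open" are said of these compounds alone.

Among the measured compounds shown here, in a toxicity assay on NIH3T3 cells (Mus musculus) for cytotoxicity, read by resazurin assay (a lower number here means that less compound is needed, a higher number that more compound is needed for the effect), compound 2 (`c1ccc(-c2ccc(Cn3cncc3CNc3cccc(-c4ccccc4)c3)cc2)cc1`) gives 10000 nM as the only number in this set. Compound 1 (`CN(C)c1ccc(NCc2cncn2Cc2ccc(-c3ccccc3)cc2)cc1-c1ccccc1`) stands at > 1000 nM which is a limit of the assay and not a number. Compound 3 (`COC(=O)c1ccc(NCc2cncn2Cc2cccc([N+](=O)[O-])c2)cc1-c1ccccc1`) stands at > 10000 nM which is likewise a limit and not a number. For the measured compounds named here, compound 3 differs from compound 2 in more than one place and gives no single step.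

Compound 4 (`c1ccc(-c2ccc(Cn3cncc3CNc3ccc(-c4ccccc4)c(-c4ccccc4)c3)cc2)cc1`) follows from compound 2 by phenyl in place of hydrogen on an aromatic carbon with phenyl in place of hydrogen on an aromatic carbon. Going by the values given here, the one measured step that bears on this change is a step that the limit leaves unreadable from compound 1 to compound 2 and it concerns hydrogen in place of dimethylamino. Compound 1 carries dimethylamino on the same carbon where compound 4 takes the phenyl, so this step is the closest guide, yet it offers no size.

The expectation therefore rests on compound 2 at 10000 nM alone. No change beyond the scatter is expected in either direction, and the estimated step is no change at the digits printed from compound 2 to compound 4 (within the scatter) in this assay for now. For compound 4 the estimate is 10000 nM with an expected range of 3000 nM to 30000 nM in this assay.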

Compound 4, half-maximal effective concentration: > 10000 nM
Compound 4 gave a limit, no number (the forecaster's own chance of this, stated with the estimate: 55%); the middle value sits exactly at the limit.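

In this assay, phenyl in place of hydrogen on this aromatic carbon, ortho to a phenyl group and para to a large group, gives a number no lower from compound 2 to compound 4 (the limit leaves the size open). Among the compounds shown here, this is the first step at this carbon whose direction can be read, and it shows that one six-membered aromatic ring of carbon only, with no hydrogen-bond donors or acceptors, does not bring the number down from that of compound 2. The reading for compound 4 is a limit of the assay and not a number: the limit of > 10000 nM in this assay, at which 2 of the 4 values shown sit.

As far as these compounds go, the steps that link compound 1 to compound 2 and to compound 4 cannot be read, so dimethylamino on this carbon cannot be ranked against hydrogen or phenyl, and how far compound 4 lies from compound 2 also stays open. Whether a carboxylic acid or a methoxy group on this same carbon would give a readable number, and on which side of compound 2 it would fall, remains an open question for the series.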